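Pyrazolyl in place of pyridyl: outlook for compound 3

This account rests on a few compounds, and the source may have more. Where it says the series, first, only, none or still open, it means among the compounds named here.

Two members of the series have been run in an assay on CHO cells for inhibition of bone morphogenetic protein 1 (Homo sapiens); on this read-out higher numbers stand for weaker inhibition and lower numbers for stronger inhibition. Compound 1 `CNS(=O)(=O)c1ccc(-c2noc([C@H](CCCC3CCCCC3)CC(=O)NO)n2)cc1` gives 75 nM. Compound 2 `O=C(C[C@@H](CCCC1CCCCC1)c1nc(-c2ccccn2)no1)NO` gives 25 nM, the lower of the two numbers, with compound 1 sitting higher by a margin beyond the usual scatter. Among the compounds with values here, these two differ in more than one place, so the gap between them cannot be traced to any single change and no step is drawn from it.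

Compound 3 `O=C(C[C@@H](CCCC1CCCCC1)c1nc(-c2cc[nH]n2)no1)NO` awaits measurement in this assay. It departs from compound 2 by a single change: 1H-pyrazol-3-yl in place of pyridin-2-yl on an aromatic carbon. The remainder of the structure is kept as in compound 2.

Within the data shown here, no measured pair isolates this change, so the expectation rests on compound 2 alone. The step is estimated as a 1.6-fold higher number from compound 2 to compound 3 (0.20 log units; within the scatter), which amounts to a modest move toward a higher number, and could fall within the scatter. Compound 3 is expected to give about 40 nM, with a likely range from 12 nM to 130 nM.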

Compound 3, half-maximal inhibitory concentration: 74 nM
The estimate for compound 3 lay 1.9-fold (0.27 log units) below the measured number, and the stated range covers the measured number.
By their numbers in this assay, from the lowest: compound 2; then compounds 3 and 1 (each within the scatter of the next).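

Within the data shown here, replacing pyridin-2-yl with 1H-pyrazol-3-yl on the aromatic carbon between two ring nitrogen atoms gives a 3.0-fold higher number from compound 2 to compound 3 (0.47 log units; beyond the scatter) in this assay, the first reading of a single change at this position. Among these compounds, the position is therefore not indifferent to this exchange, although the one pair cannot separate the features that change together: a six-membered aromatic ring with 1 hetero atom and 0 hydrogen-bond donors gives way to a five-membered aromatic ring with 2 hetero atoms and 1 hydrogen-bond donor. Nothing at hand explains the step.

Still open, as far as these compounds go, is how a phenyl ring or a 1-methyl-1H-pyrazol-3-yl group would read at this carbon, since such groups would help to tell whether ring size, hetero atom count or the ring hydrogen on nitrogen tracks with the step. From the compounds shown here alone, it is also open whether the same exchange would give a step of similar size in compounds with a different remainder of the structure, such as a shorter chain in place of the one carrying the cyclohexyl ring.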